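Swapping a Hydroxy for an Amine Chain on Sulfonyl

The source may report more compounds than this note shows. Statements on the series, on what has been measured and on what is new or still open speak of the compounds shown alone.

Of the compounds shown here, three have been measured in an assay for binding affinity to adenosine receptor A1 (Bos taurus); a higher number here means a weaker inhibitor, a lower number a stronger inhibitor. Compound 1 `C=CCn1c(=O)c2nc(-c3ccc(Cl)cc3N)[nH]c2n(CC=C)c1=O` gives 0.8 nM in this assay, and compound 3 `Cc1cccc(-c2nc3c(=O)n(C)c(=O)n(C)c3[nH]2)c1` gives 13 nM. Compound 2 `CCn1c(=O)c2nc(-c3cccc(S(=O)(=O)O)c3)[nH]c2n(CC)c1=O` gives 8420 nM, which is the highest of the three numbers: its nearest neighbour is compound 3, and that gap is already beyond the scatter, while the gap to compound 1 is wider still. Compound 2 is thus the weakest binder of the three.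

Compound 4 `CCn1c(=O)c2nc(-c3cccc(S(=O)(=O)NCCN(C)C)c3)[nH]c2n(CC)c1=O` has not yet been measured. It differs from compound 2 in one place: (2-(dimethylamino)ethyl)amino in place of hydroxy on a sulfonyl sulfur. Within the data shown here, no pair of measured compounds shows this same change, so the expectation rests on where compound 2 stands rather than on a comparable step.

Because compound 2 gives 8420 nM while compound 3 gives 13 nM, there is room for a large move downward. Compound 4 is expected to give a lower number than compound 2, with the estimated step of a 21-fold lower number from compound 2 to compound 4 (1.32 log units; beyond the scatter) lying beyond the scatter. Compound 4 is therefore estimated at about 400 nM in this assay, with a plausible range from 60 nM to 2500 nM.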

Compound 4, half-maximal inhibitory concentration: 29.4 nM
Estimate against measurement, compound 4: 14-fold (1.13 log units) above; the whole stated range lies above it.
By their numbers in this assay, from the lowest: compound 1; then compound 3; then compound 4; then compound 2.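

On the sulfonyl sulfur, (2-(dimethylamino)ethyl)amino in place of hydroxy gives a 290-fold lower number from compound 2 to compound 4 (2.46 log units; beyond the scatter) in this assay, a large change from a single exchange. The sulfonyl stays on the same aromatic carbon and the rest of the molecule is unchanged, so the weak binding of compound 2 is not set by the shared core alone: this one position can shift the number far beyond the scatter. Nothing shown here explains why the step from sulfo to (2-(dimethylamino)ethyl)sulfamoyl is so large.

The compounds shown leave open whether the step needs the dimethylamino end of the chain or comes from replacing hydroxy with any amine on the sulfur; a plain unsubstituted sulfamoyl group or an ethylamino group on the sulfonyl would help separate these two readings. Also open, as far as these compounds go, is how the number responds to a longer chain between the sulfonamide nitrogen and the dimethylamino group, or to a morpholine ring in place of that dimethylamino group.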